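From Propyl to Butyl on the Amide Chain

This account rests on a few compounds, and the source may have more. Where it says the series, first, only, none or still open, it means among the compounds named here.

In a functional assay on Huh-7 cells (Homo sapiens) for antiproliferative activity, read by CCK-8 assay, with a stated time of 72 h (a higher number here means a weaker inhibitor of growth, a lower number a stronger inhibitor of growth), compound 1 `CCC1C(=O)N(C)c2cnc(-n3ccc4cc(C(=O)NC)ccc43)nc2N1c1ccn(C)n1` gives 13200 nM and compound 2 `CCCNC(=O)c1ccc2c(ccn2-c2ncc3c(n2)N(c2ccn(C)n2)C(CC)C(=O)N3C)c1` gives 7280 nM so the two stand within the scatter of each other. Compound 3 `CCCCNC(=O)c1ccc2c(ccn2-c2ncc3c(n2)N(c2ccn(C)n2)C(CC)C(=O)N3C)c1` departs from compound 2 by a single change methyl in place of hydrogen on a saturated chain carbon, three bonds along the chain from an amide-type nitrogen which is methyl in place of hydrogen on a saturated chain carbon, three bonds along the chain from an amide-type nitrogen, and reads as propyl to butyl. Among the measured compounds shown here, one measured step bears on it, made on the same chain: a 1.8-fold lower number from compound 1 to compound 2 (0.26 log units; within the scatter) and it stayed within the scatter. For the measured compounds named here, that single step is the only guide, so no shift beyond the scatter is expected here. The expected step is a 1.1-fold lower number from compound 2 to compound 3 (0.05 log units; within the scatter) by this estimate. For compound 3 the estimate is 6500 nM and the expected range runs from 2800 nM to 15000 nM at this stage.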

Compound 3, concentration for 50% growth inhibition: 8670 nM
The estimate for compound 3 lay 1.3-fold (0.13 log units) below the measured number; the measured number falls inside the stated range.
By their numbers in this assay, from the lowest: compounds 2, 3 and 1 (each within the scatter of the next).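

In this assay, methyl in place of hydrogen on a saturated chain carbon, three bonds along the chain from an amide-type nitrogen, gives a 1.2-fold higher number from compound 2 to compound 3 (0.08 log units; within the scatter), so propyl and butyl cannot be told apart at this place. Taken from the methyl of compound 1 to the butyl of compound 3, the longer span gives a 1.5-fold lower number from compound 1 to compound 3 (0.18 log units; within the scatter), and it too stays within the scatter, so across these three compounds chain length produces no difference that can be read. No measurement shown here offers an explanation for this flat reading.

From the compounds shown here alone, whether a longer chain such as hexyl would depart from this level remains open. So does whether a chain ending in an amine or a carboxylic acid would move the number beyond the scatter.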